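Methylating the aromatic nitrogen of compound 3

The source may report more compounds than this note shows. Statements on the series, on what has been measured and on what is new or still open speak of the compounds shown alone.

Three compounds share one core and differ only in the ring hung from it. In an assay on COS-7 cells for inhibition of patatin-like phospholipase domain-containing protein 2 (Mus musculus), tested at 200 uM (on this read-out higher numbers stand for more inhibition at the one concentration tested (going by the name of the read-out) and lower numbers for less inhibition), compound 1 `CCOC(=O)c1cccc(-c2ccc(OCC)cc2)c1` gives 87%, compound 2 `CCOC(=O)c1cccc(-c2ccc(C)cc2)c1` gives 63%, and compound 3 `CCOC(=O)c1cccc(-c2ccc3[nH]ccc3c2)c1` gives 80%. Compound 3 thus holds the second highest of the three numbers: its nearest neighbour is compound 1, which stands higher by an amount within the scatter, while compound 2 lies furthest, lower by a margin beyond the scatter. Going by the values given here, the only step between measured compounds that differ in one place is a number 24 percentage points lower from compound 1 to compound 2 (beyond the scatter).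

The next compound is compound 4 `CCOC(=O)c1cccc(-c2ccc3c(ccn3C)c2)c1`. It differs from compound 3 by methyl in place of hydrogen on an aromatic nitrogen. Among the compounds with values here, no measured step concerns this aromatic nitrogen or the fused two-ring system; the single recorded step involves a different place and a different pair of groups, so it offers little guidance for the change from compound 3 to compound 4. The step of a number 5 percentage points lower from compound 3 to compound 4 (within the scatter) is therefore expected to remain within the scatter, with no clear direction. In this assay compound 4 is estimated at 75%, within a range from 55% to 92%.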

Compound 4, a percentage reported as inhibition, at one concentration (the size of the read-out at that concentration, not a potency): 84%
Compound 4: middle estimate off by 9 percentage points, on the low side; the measured number falls inside the stated range.
By their numbers in this assay, from the lowest: compound 2; then compounds 3, 4 and 1 (each within the scatter of the next).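

In this assay, methyl in place of hydrogen on an aromatic nitrogen comes with a number 4 percentage points higher from compound 3 to compound 4 (within the scatter), so on this read-out the two compounds cannot be told apart. Going by these compounds alone, this gives the first information on this position: the hydrogen on the nitrogen of the five-membered aromatic ring is not needed for a reading of this size, and with a single added carbon there the number stays level at the one concentration tested, although a reading at one concentration is not a potency and a difference between the two compounds in potency could lie hidden behind it. No measurement at hand explains why the two readings match.

The compounds shown leave open whether other groups on the aromatic nitrogen would keep the number level, for instance whether an ethyl group, a longer chain or a chain ending in an amine would give a reading within the scatter of that of compound 3. They also leave open what a carboxylic acid in place of the ester on the shared core would do, since all four compounds carry that same ester.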